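Dimethoxy to Dihydroxy on the Aryl Ether Arm

This account rests on a few compounds, and the source may have more. Where it says the series, first, only, none or still open, it means among the compounds named here.

Three compounds have been measured in a functional assay on RS4-11 cells (Homo sapiens) for inhibition, read by CCK-8 assay, with a stated time of 48 h; on this read-out higher numbers stand for weaker inhibition and lower numbers for stronger inhibition:

compound 1, `O=C(NCCNS(=O)(=O)c1ccc(-c2ccccc2O[C@H]2CC[C@H](O)CC2)s1)Nc1cc(Cl)cc(Cl)c1`, gives 14100 nM
compound 2, `COc1ccc(Oc2ccc(C(C)C)cc2-c2ccsc2S(=O)(=O)NCCNC(=O)Nc2cc(Cl)cc(Cl)c2)cc1OC`, gives 9000 nM
compound 3, `O=[N+]([O-])c1ccc(Oc2ccccc2-c2ccc(S(=O)(=O)NCCNC(=S)Nc3cccc(Cl)c3)s2)cc1`, gives only the limit > 50000 nM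

Among the two numbers in this assay, compound 2 carries the lower one, but the value of compound 1 sits within the usual scatter of it, so the two cannot be ranked against each other. The value of compound 3 is a limit of the assay and not a number, as noted in the limit of > 50000 nM in this assay, at which 1 of the 3 values shown sits.

Compound 4, `CC(C)c1ccc(Oc2ccc(O)c(O)c2)c(-c2ccsc2S(=O)(=O)NCCNC(=O)Nc2cc(Cl)cc(Cl)c2)c1`, differs from compound 2 in one place: 3,4-dihydroxyphenyl in place of 3,4-dimethoxyphenyl on an oxygen on an aromatic ring. Among the compounds with values here, no step between two measured compounds mirrors this change, so the evidence for it is indirect. The step from compound 2 to compound 4 in this assay is expected to be small, a 1.1-fold lower number from compound 2 to compound 4 (0.05 log units; within the scatter), with no clear direction beyond the scatter. Compound 4 is therefore estimated at 8000 nM, within a range from 2500 nM to 25000 nM.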

Compound 4, half-maximal inhibitory concentration: 6400 nM
For compound 4 the middle estimate is 1.3-fold (0.10 log units) above the measured one; the range from low to high includes it.
By their numbers in this assay, from the lowest: compounds 4, 2 and 1 (each within the scatter of the next, the first and the last beyond it). At a limit, above all of these: compound 3.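

In this assay, within the data shown here, this is the first single-place step: a 1.4-fold lower number from compound 2 to compound 4 (0.15 log units; within the scatter). The earlier compounds shown here differ from one another in several places, so they could not show that this position on an oxygen on an aromatic ring accepts 3,4-dihydroxyphenyl, with its hydrogen-bond donors, in place of 3,4-dimethoxyphenyl without a change beyond the scatter. Nothing shown here accounts for the size of this step.

The compounds shown leave open whether any replacement at this position can shift the number beyond the scatter, for example a phenyl ring carrying an amine or a carboxylic acid. They also leave open whether the same exchange would give a similar step on a different core.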